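Exchanging the 2-chlorophenyl group of compound 1 for 4-methylphenyl

The source may hold more compounds than are shown below. What is called first, only, known or untested is meant among the compounds shown, and "the series" means these compounds.

Compound 1 `Clc1ccc(-c2cc(-c3cccs3)nc(-c3ccccc3Cl)c2)o1` gives 6190 nM in a functional assay on HCT-15 cells (Homo sapiens) for cytotoxicity, in the presence of a further agent that is not named here (a lower number here means a stronger inhibitor, a higher number a weaker inhibitor), and stands highest of the two numbers available. Compound 2 `Clc1ccc(-c2cc(-c3ccsc3)nc(-c3ccccc3Cl)c2)o1` gives 4570 nM in this assay, and the step of a 1.4-fold lower number from compound 1 to compound 2 (0.13 log units; within the scatter) lies within the scatter. Compound 3 `Clc1ccc(-c2cc(-c3ccsc3)nc(-c3ccco3)c2)o1` reaches only a limit in this assay, > 50000 nM. The step of an at least 10-fold higher number from compound 2 to compound 3 (1.03 log units; beyond the scatter) is large. Compound 4 `Cc1ccc(-c2cc(-c3ccc(Cl)o3)cc(-c3cccs3)n2)cc1` differs from compound 1 in one place: 4-methylphenyl in place of 2-chlorophenyl on an aromatic carbon. Of the measured steps, an at least 10-fold higher number from compound 2 to compound 3 (1.03 log units; beyond the scatter) bears on this change, since it too removes the 2-chlorophenyl group from that carbon; the step of a 1.4-fold lower number from compound 1 to compound 2 (0.13 log units; within the scatter) concerns another position. The entering 4-methylphenyl keeps a six-membered aromatic ring of carbon only, so a smaller loss than in that step is expected. Compound 4 is therefore expected to give 11000 nM, with a range from 4000 nM to 30000 nM. This estimate means a step of a 1.8-fold higher number from compound 1 to compound 4 (0.25 log units; within the scatter), expected to be modest.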

Compound 4, half-maximal inhibitory concentration: 9890 nM
Compound 4: middle estimate off by 1.1-fold (0.05 log units), on the high side, and the stated range covers the measured number.
By their numbers in this assay, from the lowest: compounds 2, 1 and 4 (each within the scatter of the next, the first and the last beyond it). At a limit, above all of these: compound 3.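

On an aromatic carbon next to the ring nitrogen, 4-methylphenyl can replace 2-chlorophenyl with no change beyond the scatter in this assay: a 1.6-fold higher number from compound 1 to compound 4 (0.20 log units; within the scatter). Losing the 2-chlorophenyl group from this carbon therefore does not by itself bring the large loss seen with furan-2-yl. Nothing measured here gives a reason for this step.

On these data alone, it remains open whether an amine or a carboxylic acid on the entering six-membered aromatic ring would keep the number in this range. Also open, as far as these compounds go, is whether 4-methylphenyl would behave the same way alongside thiophen-3-yl.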